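The compounds below may be only part of what the source reports. "The series", "measured", "known", "first", "only" and "open" are said of these compounds alone.

Compound 1 `N#C/N=C(\NCc1ccc(S(=O)(=O)c2cccc(C(F)(F)F)c2)cc1)Nc1ccncc1` gives 74% in an ADME assay on microsomes from liver (Mus musculus) for metabolic stability, with a stated time of 30 min, tested at 1 uM; a lower number here means that less of the compound is left, a higher number that more of the compound is left. Among the measured compounds shown here, compound 2 `N#C/N=C(\NCc1ccc(S(=O)(=O)c2ccccc2)cc1)Nc1ccncc1` gives 57% in this assay, which is a number 17 percentage points lower from compound 1 to compound 2 (beyond the scatter); on the two numbers so far compound 2 is the lower of the pair. Compound 3 `N#C/N=C(\NCc1ccc(S(=O)(=O)N2CC3CCC(C2)O3)cc1)Nc1ccncc1` follows from compound 2 by a change at a different place: a group of 8 heavy atoms (6 carbon, 1 nitrogen, 1 oxygen; one five-membered non-aromatic ring with 1 hetero atom, one six-membered non-aromatic ring with 2 hetero atoms) in place of a group of 6 heavy atoms (6 carbon; one six-membered aromatic ring of carbon only), on a sulfonyl sulfur. For the measured compounds named here, the only measured step, a number 17 percentage points lower from compound 1 to compound 2 (beyond the scatter), concerns a substituent on an aromatic carbon of the other ring and leaves the group on the sulfonyl sulfur untouched, so no measured step bears directly on this change. With nothing to anchor a direction, the expected step for compound 3 is a number 2 percentage points lower from compound 2 to compound 3 (within the scatter), that is, no shift beyond the usual scatter, held with low confidence. Compound 3 is therefore estimated at 55% in this assay, within a range of 30% to 80%.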

Compound 3, percent of the compound remaining: 12%
For compound 3 the middle estimate is 43 percentage points above the measured one; the whole stated range lies above it.
By their numbers in this assay, from the lowest: compound 3; then compound 2; then compound 1.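

In this assay the group on a sulfonyl sulfur proves to be a far stronger lever than anything seen so far: with phenyl replaced by the non-aromatic two-ring group holding nitrogen and oxygen, the result is a number 45 percentage points lower from compound 2 to compound 3 (beyond the scatter). Against the trifluoromethyl-bearing aromatic group, the same entering group gives a number 62 percentage points lower from compound 1 to compound 3 (beyond the scatter), so both aromatic groups on this sulfur stand above it, beyond the scatter. Nothing available explains this loss.

Open, from the compounds shown here alone, is which feature of the entering group goes with the lower number: the loss of the aromatic ring, the ring oxygen or the two-ring shape. A piperidine, a morpholine or a cyclohexyl group on the sulfonyl sulfur would separate these, and the compounds shown do not tell whether trifluoromethyl would matter on any such group.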